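Methyl on the Piperidine Ring: An Expected Cytotoxicity Value

The source may report more compounds than this note shows. Statements on the series, on what has been measured and on what is new or still open speak of the compounds shown alone.

Measured compounds:
Compound 1, `COc1cc2c(Oc3ccc(NC(=O)c4nnn(-c5ccccc5C(F)(F)F)c4C)cc3F)ccnc2cc1OCCCN1CCCC1`: 1060 nM
Compound 2, `COc1cc2c(Oc3ccc(NC(=O)c4nnn(-c5ccc(F)c(F)c5)c4C(F)(F)F)cc3F)ccnc2cc1OCCCN1CCCCC1`: 1210 nM

Of the compounds shown here, two have been measured in a functional assay on U-87MG ATCC cells (Homo sapiens) for cytotoxicity, read by MTT assay, with a stated time of 72 h; on this read-out higher numbers stand for weaker inhibition and lower numbers for stronger inhibition. In this assay compound 1 gives 1060 nM. In this assay compound 2 gives 1210 nM. On these two numbers compound 2 stands at the top, but the gap to compound 1 is within the scatter, so the two cannot be told apart on this read-out.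

Compound 3, `COc1cc2c(Oc3ccc(NC(=O)c4nnn(-c5ccc(F)c(F)c5)c4C(F)(F)F)cc3F)ccnc2cc1OCCCN1CCC(C)CC1`, has not yet been measured. It differs from compound 2 in one place: methyl in place of hydrogen on a saturated ring carbon. For the measured compounds named here, no step between measured compounds is known here, and nothing among the measured compounds shows what such a change does on this ring.

Going by the values given here, with no step to lean on, the expected step in this assay from compound 2 to compound 3 is a 1.0-fold lower number from compound 2 to compound 3 (0.00 log units; within the scatter), which is none beyond the scatter. Compound 3 is therefore estimated at 1200 nM, with a range from 500 nM to 3000 nM.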

Compound 3, half-maximal inhibitory concentration: 1150 nM
For compound 3 the middle estimate is 1.0-fold (0.02 log units) above the measured one; low and high end bracket the measured number.
By their numbers in this assay, from the lowest: compounds 1, 3 and 2 (each within the scatter of the next).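

For the compounds shown here, the change from piperidin-1-yl to 4-methylpiperidin-1-yl is the first single-place comparison available in this assay, and it amounts to a 1.1-fold lower number from compound 2 to compound 3 (0.02 log units; within the scatter). For this pair, then, a methyl on the saturated ring carbon three ring bonds from the ring nitrogen produces no difference that this cytotoxicity read-out can separate from the ordinary spread of repeated measurements, which the two earlier compounds alone could not show. No measurement shown here offers an explanation for this outcome.

Going by these compounds alone, this is only one pair, so it leaves open what other groups on the same carbon would do, such as a hydroxyl, an amine, a carboxylic acid or a longer chain like ethyl, and whether a methyl on a different carbon of the piperidine ring would give a similar result. It also leaves open whether the same methyl change would read the same way with other parts of the molecule altered, since compound 1 differs from compound 2 in more than one place and cannot serve as a test of this.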